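Metabolic stability notes on three measured compounds and one pending

A few compounds are considered here, and "the series" means these few. Any claim that something is new, unique, unknown or untested is made for them only; others in the source may bear on it.

Measured in an ADME assay on microsomes from liver (Homo sapiens) for metabolic stability, tested at 2.5 uM; a lower number here means slower removal, a higher number faster removal of the compound:
compound 1 `O=S(=O)(c1ccc(F)c(Cl)c1)c1cnc2cc(F)ccc2c1-c1cccc(Cl)c1`: 0.66 mL/min
compound 2 `COc1ccc(-c2c(S(=O)(=O)c3cc(F)cc(F)c3)cnc3c(F)cccc23)cc1`: 2.59 mL/min
compound 3 `O=S(=O)(c1ccc(F)cc1)c1cnc2c(F)cccc2c1-c1cccc(Cl)c1`: 1.21 mL/min

Compound 3 stands second highest of the three numbers. Its gap to compound 1 lies within the scatter; compound 2 gives a higher number than compound 3, beyond the scatter.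

Compound 4 `COc1ccc(-c2c(S(=O)(=O)c3ccc(F)cc3)cnc3c(F)cccc23)cc1` is not yet measured. It differs from compound 3 in one place: 4-methoxyphenyl in place of 3-chlorophenyl on an aromatic carbon. Compound 2 also carries 4-methoxyphenyl and gives the highest number of the three, but compound 2 and compound 4 differ in other places as well, so no firm pattern is drawn.

The step from compound 3 to compound 4 is expected to be upward, a 1.7-fold higher number from compound 3 to compound 4 (0.22 log units; within the scatter), near the edge of the scatter. Compound 4 is estimated at 2 mL/min, with a range from 1 mL/min to 4 mL/min.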

Compound 4, intrinsic clearance in a liver preparation (reported as CLH), per the amount of preparation that the assay uses: 2.41 mL/min
For compound 4 the middle estimate is 1.2-fold (0.08 log units) below the measured one; measured number inside the range.
By their numbers in this assay, from the lowest: compounds 1, 3, 4 and 2 (each within the scatter of the next, the first and the last beyond it).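

In this assay, among these compounds, 4-methoxyphenyl in place of 3-chlorophenyl on the aromatic carbon opposite the ring nitrogen gives a 2.0-fold higher number from compound 3 to compound 4 (0.30 log units; within the scatter) and so provides the first single-place reading at this position, one that stays inside the scatter. With 4-methoxyphenyl held at this position, 4-fluorophenyl in place of 3,5-difluorophenyl on the sulfonyl sulfur gives a 1.1-fold lower number from compound 2 to compound 4 (0.03 log units; within the scatter) and separates the two compounds no more than repeat measurements would.

No supporting data bear on these readings. From the compounds shown here alone, whether an amine or a carboxylic acid on this aromatic carbon would read apart from either aryl group remains open.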